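The compounds below may be only part of what the source reports. "The series", "measured", "known", "first", "only" and "open" are said of these compounds alone.

Going by the values given here, in a functional assay on UCI101 cells (Homo sapiens) for cytotoxicity, read by resazurin assay, with a stated time of 48 h (on this read-out higher numbers stand for weaker inhibition and lower numbers for stronger inhibition), compound 1 (`COc1cc(/C=C\c2ccc3cc[nH]c3c2)cc(OC)c1`) gives 250 nM, the higher of the two numbers so far, while compound 2 (`COc1cc(/C=C\c2ccc3c(ccn3C)c2)cc(OC)c1`) gives 40 nM, a gap beyond the usual scatter. Compound 3 (`COc1cc(/C=C\c2ccc3ccn(C)c3c2)cc(OC)c1`) departs from compound 1 in one place: methyl in place of hydrogen on an aromatic nitrogen. Compound 1 differs from compound 2 in more than one place, yet compound 2 also bears that methyl, so its 40 nM offers only a loose guide. A moderate drop is expected, an estimated 2.5-fold lower number from compound 1 to compound 3 (0.40 log units; beyond the scatter). Compound 3 is expected at 100 nM, with a likely range from 25 nM to 400 nM.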

Compound 3, half-maximal inhibitory concentration: 220 nM
For compound 3 the middle estimate is 2.2-fold (0.34 log units) below the measured one, within the range that was stated.
By their numbers in this assay, from the lowest: compound 2; then compounds 3 and 1 (each within the scatter of the next).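

In this assay, methyl in place of hydrogen on an aromatic nitrogen of the five-membered aromatic ring gives a 1.1-fold lower number from compound 1 to compound 3 (0.06 log units; within the scatter), so compound 1 and compound 3 cannot be told apart on this read-out. This one-place comparison shows that, at this nitrogen, the hydrogen and the methyl give numbers within the scatter of each other. No available measurement explains this result. On these data alone, whether a longer chain such as ethyl, or an acetyl group, on this same nitrogen would give a similar number remains open.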